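The source may hold more compounds than are shown below. What is called first, only, known or untested is meant among the compounds shown, and "the series" means these compounds.

Among the compounds with values here, in a functional assay on ileum (strain Hartley) for agonist activity at 5-hydroxytryptamine receptor 3A (Cavia porcellus) (on this read-out higher numbers stand for higher potency (the scale is a negative logarithm) and lower numbers for lower potency), compound 2 `CN1CCN(c2nc3cc(Br)ccc3o2)CC1` gives 6.21, the only number obtained so far. For compound 1 `CCc1ccc2oc(N3CCN(C)CC3)nc2c1` the result in this assay is only a limit, < 4. The step of a number at least 2.21 log units higher from compound 1 to compound 2 (beyond the scatter) thus rests on that limit (the limit of < 4 in this assay, at which 1 of the 2 values shown sits). Compound 3 `CC(=O)c1ccc2oc(N3CCN(C)CC3)nc2c1` differs from compound 2 by acetyl in place of bromo on an aromatic carbon. Within the data shown here, the one measured step bears on this change only in showing that exchanging the group at this position can move this assay by a large amount; no measured pair contains acetyl, so direction is open. The estimate for compound 3 is 5.3, between 4 and 6.4, an expected step of a number 0.91 log units lower from compound 2 to compound 3 (beyond the scatter).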

Compound 3, negative logarithm of the half-maximal effective concentration: < 4
Compound 3 ended at the assay's limit; the forecaster's own chance of this, stated with the estimate: 30%; at least 1.30 log units between middle value and limit.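

In this assay, acetyl in place of bromo on this aromatic carbon settles the direction left open so far, with a number at least 2.21 log units lower from compound 2 to compound 3 (beyond the scatter). The result for compound 3, < 4, is a limit of the assay. Of the three groups shown at this position, only bromo gives a number, and the other two give limits: the limit of < 4 in this assay, at which 2 of the 3 values shown sit.

The step between ethyl and acetyl cannot be read from the two limits. From the compounds shown here alone, whether chloro, iodo or an amine at this position gives a number in this assay stays open.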